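Compound 3 to compound 4: a larger amide group

The compounds below may be only part of what the source reports. "The series", "measured", "known", "first", "only" and "open" are said of these compounds alone.

- Compound 1 `CN(C)S(=O)(=O)c1ccccc1Nc1cc(-c2ccc3ccn(C)c3c2)c2nccnc2c1` gives 2 ug/mL
- Compound 2 `Cn1ccc2ccc(-c3cc(Nc4ccccc4S(=O)(=O)Nc4cncnc4)cc4nccnc34)cc21` gives 254 ug/mL
- Compound 3 `CN(C)C(=O)c1ccncc1Nc1cc(-c2ccc3ccn(C)c3c2)c2nccnc2c1` gives 175 ug/mL

In a physicochemical assay for solubility, read by spectrophotometry, measured as kinetic solubility, at pH 8, tested at 500 uM (on this read-out higher numbers stand for higher solubility and lower numbers for lower solubility), compound 3 gives 175 ug/mL. This lies within the scatter of compound 2 and far beyond the scatter from compound 1. Compound 4 `CC(=O)N1CCC(NC(=O)c2ccncc2Nc2cc(-c3ccc4ccn(C)c4c3)c3nccnc3c2)CC1` has not yet been measured. It carries (1-acetylpiperidin-4-yl)amino in place of dimethylamino on a carbonyl carbon.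

For the measured compounds named here, only one measured step bears on this change, and only loosely. That step, a 130-fold higher number from compound 1 to compound 2 (2.10 log units; beyond the scatter), is large and also removes dimethylamino, but from a sulfonyl sulfur and with a different incoming group. Compound 3 keeps dimethylamino and still stands at 175 ug/mL, so a repeat of that large rise is not expected. No step beyond the scatter is expected in this assay, in either direction. The expected change is a 1.2-fold lower number from compound 3 to compound 4 (0.07 log units; within the scatter). For compound 4 the estimated value is 150 ug/mL, with an expected range from 50 ug/mL to 270 ug/mL.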

Compound 4, solubility: 213 ug/mL
Compound 4: the middle estimate sits 1.4-fold (0.15 log units) below what was measured; measured number inside the range.
By their numbers in this assay, from the lowest: compound 1; then compounds 3, 4 and 2 (each within the scatter of the next).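

In this assay, the step on this carbonyl carbon, a 1.2-fold higher number from compound 3 to compound 4 (0.09 log units; within the scatter), shows that dimethylamino can give way to the much larger (1-acetylpiperidin-4-yl)amino, with its six-membered non-aromatic ring and one added hydrogen-bond donor, without the read-out leaving the scatter. For the compounds shown here, the earlier compounds could not show this: compound 3 offered only dimethylamino on a carbonyl carbon, and the one earlier step concerned a sulfonyl sulfur. No measurement at hand accounts for this result. The compounds shown leave open what the acetyl contributes, since a free piperidine amine on the same ring has no counterpart here. They also leave open whether a carboxylic acid or a longer open chain in place of the ring would stay within the scatter of compound 3.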